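Swapping the Aryl Group on the Core for Compound 3

The source may report more compounds than this note shows. Statements on the series, on what has been measured and on what is new or still open speak of the compounds shown alone.

In a functional assay on CHO cells for agonist activity at adenosine receptor A1 (Homo sapiens), read by fluorescence and ERK phosphorylation, with stated times of 30 min and 1.5 h, tested at 3 uM (on this read-out lower numbers stand for a weaker effect and higher numbers for a stronger effect at the one concentration tested), two compounds have been measured so far:

compound 1, `Nc1scc(-c2cccc(F)c2)c1C(=O)c1ccccc1`, gives 51%
compound 2, `Nc1scc(-c2cccc(F)c2)c1C(=O)c1ccc(Cl)cc1`, gives 76%

Going by the values given here, compound 2 stands highest of these two numbers; its nearest neighbour is compound 1, and the single step of a number 25 percentage points higher from compound 1 to compound 2 (beyond the scatter) lies beyond the scatter, so compound 2 is the stronger of the pair at the concentration tested.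

Compound 3 is `Nc1scc(-c2ccc(Br)cc2)c1C(=O)c1ccc(Cl)cc1`. It keeps the chloro-bearing ring of compound 2 and changes the other aryl group: 4-bromophenyl in place of 3-fluorophenyl on an aromatic carbon. Among the compounds with values here, this change sits on an aromatic carbon of a five-membered aromatic ring with 1 sulfur, a position that no measured step touches. Within the data shown here, the one measured step concerns the chloro substituent and says nothing about exchanging 3-fluorophenyl for 4-bromophenyl, so there is no basis for expecting a step beyond the scatter in either direction, and the uncertainty is wide.

Compound 3 is therefore expected to give about 70%, within 45% to 95%, meaning an estimated step of a number 6 percentage points lower from compound 2 to compound 3 (within the scatter).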

Compound 3, a percentage reported as activity, at one concentration (the size of the read-out at that concentration, not a potency): 45%
The estimate for compound 3 lay 25 percentage points above the measured number; low and high end bracket the measured number.
By their numbers in this assay, from the lowest: compounds 3 and 1 (each within the scatter of the next); then compound 2.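

The aryl position on the shared core is not a silent one: in this assay, exchanging 3-fluorophenyl for 4-bromophenyl gives a number 31 percentage points lower from compound 2 to compound 3 (beyond the scatter) even though the chloro-bearing ring stays in place. So the read-out responds to this position as well as to the chloro substituent, the only place that had been probed before. The two groups match in what is counted here, with 7 heavy atoms, one six-membered aromatic ring of carbon only, no hydrogen-bond donors or acceptors and no net charge, so these counts do not separate them, and no available measurement accounts for the difference.

The change swaps the halogen and moves it on the phenyl ring in a single step, so the compounds shown leave open which of the two matters, a question that 3-bromophenyl or 4-fluorophenyl at the same position could settle. Also open, going by these compounds, is how this position would respond to an unsubstituted phenyl or to a phenyl carrying an amine or a carboxylic acid, and whether any of these differences would hold at other concentrations.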